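Swapping Cyclopentyl for 3-Hydroxypropyl in Compound 2

The compounds below may be only part of what the source reports. "The series", "measured", "known", "first", "only" and "open" are said of these compounds alone.

In a functional assay on KBVIN cells (Homo sapiens) for antiproliferative activity, read by sulforhodamine B assay, with a stated time of 48 h (on this read-out higher numbers stand for weaker inhibition of growth and lower numbers for stronger inhibition of growth), compound 2 (`COc1ccc(N(C)c2nc(NC3CCCC3)c3ccccc3n2)cc1`) gives 10100 nM and compound 1 (`COc1ccc(Nc2nc(NCCCO)c3ccccc3n2)cc1`) gives 17100 nM as numbers within the usual scatter of each other. Going from compound 2 to compound 3 (`COc1ccc(N(C)c2nc(NCCCO)c3ccccc3n2)cc1`) puts 3-hydroxypropyl in place of cyclopentyl on a nitrogen on an aromatic ring. Among the compounds with values here, no measured pair shows this change alone, so only a small rise in the number, none beyond the scatter, is expected in this assay for this change. That expected step (a 1.2-fold higher number from compound 2 to compound 3 (0.07 log units; within the scatter)) is an estimate only. Compound 3 is estimated at 12000 nM (range 4000 nM to 30000 nM).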

Compound 3, concentration for 50% growth inhibition: 30800 nM
Estimate against measurement, compound 3: 2.6-fold (0.41 log units) below; the measured number lies above the stated range.
By their numbers in this assay, from the lowest: compounds 2, 1 and 3 (each within the scatter of the next, the first and the last beyond it).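

Putting 3-hydroxypropyl in place of cyclopentyl on a nitrogen on an aromatic ring gives a 3.0-fold higher number from compound 2 to compound 3 (0.48 log units; beyond the scatter), so in this assay this position responds to the change by more than the scatter. Methyl in place of hydrogen on a nitrogen on an aromatic ring gives a 1.8-fold higher number from compound 1 to compound 3 (0.26 log units; within the scatter), so that change shows no clear effect here. Nothing in the data shown explains either step.

The compounds shown leave open whether the larger step follows the hydroxyl or the loss of the ring; a plain propyl chain would help separate the two. From the compounds shown here alone, how an amine at the end of the chain would read also stays open.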